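Swapping Cyclohexyl for Benzyl on Two Related Cores

This account rests on a few compounds, and the source may have more. Where it says the series, first, only, none or still open, it means among the compounds named here.

Compound 1 `COc1ccc(-c2cc(NC(=O)COCC(=O)N(C)CC(=O)NC3CCCCC3)nc(-c3ccc(OC)cc3)n2)cc1` and compound 2 `COc1ccc(-c2cc(NC(=O)COCC(=O)N(C)CC(=O)NCc3ccccc3)nc(-c3ccc(OC)cc3)n2)cc1` share one core; compound 3 `COc1ccc(-c2cc(NC(=O)CCC(=O)N3CCN(CC(=O)NC4CCCCC4)CC3)nc(-c3ccc(OC)cc3)n2)cc1` and compound 4 `COc1ccc(-c2cc(NC(=O)CCC(=O)N3CCN(CC(=O)NCc4ccccc4)CC3)nc(-c3ccc(OC)cc3)n2)cc1` share another, and the difference between the two cores is not broken down here. In an assay on HeLa cells for displacement of a labelled ligand from adenosine receptor A3 (Homo sapiens), read by fluorescence polarization, with a stated time of 30 min (a higher number here means a weaker inhibitor, a lower number a stronger inhibitor), compound 1 gives 10100 nM and compound 2 gives 19000 nM. The change that separates them, (benzyl in place of cyclohexyl on an amide-type nitrogen), made a 1.9-fold higher number from compound 1 to compound 2 (0.27 log units; within the scatter). In this assay compound 3 gives 10500 nM. Compound 4 carries the same change on its own core, (benzyl in place of cyclohexyl on an amide-type nitrogen), at a place described in identical words, so the same change is being repeated rather than a merely similar one. Because the earlier step of a 1.9-fold higher number from compound 1 to compound 2 (0.27 log units; within the scatter) stayed within the scatter, the expected step in this assay is a 1.6-fold higher number from compound 3 to compound 4 (0.21 log units; within the scatter). Compound 4 is therefore estimated at 17000 nM, with a likely range from 8000 nM to 40000 nM.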

Compound 4, inhibition constant: 3400 nM
Beside the measured number, compound 4's estimate is 5.0-fold (0.70 log units) above it; measured number outside the range, below it.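

Putting benzyl in place of cyclohexyl on an amide-type nitrogen gives a 3.1-fold lower number from compound 3 to compound 4 (0.49 log units; beyond the scatter) in this assay. The size and direction of this change therefore do not carry over reliably from one core to the other in this series, as the two steps show: the same change on two cores in this assay, a 1.9-fold higher number (0.27 log units; within the scatter) from compound 1 to compound 2 and a 3.1-fold lower number (0.49 log units; beyond the scatter) from compound 3 to compound 4, 5.8-fold (0.76 log units) apart, beyond the scatter of two such steps
For the compounds shown here, this rests on only one pair of compounds per core, and it does not show which part of the cores matters or why the two steps differ.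

The compounds shown leave open how another group at this place, such as a phenylethyl group or a simple methyl, would behave on each core. Also open, going by these compounds, is whether the benzyl gain seen with compound 4 would hold on further cores.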